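The source may report more compounds than this note shows. Statements on the series, on what has been measured and on what is new or still open speak of the compounds shown alone.

Measured compounds:
compound 1 `COc1ccc(C2=NN(c3ccccc3)C(c3ccc(C)cc3)C2S(=O)(=O)CC2=NCCO2)cc1`, 64.3% in a functional assay, tested at 75 ug/mL; on this read-out higher numbers stand for a stronger effect at the one concentration tested and lower numbers for a weaker effect
compound 3 `COc1ccc(C2=NN(c3ccccc3)C(c3ccc(C)cc3)C2S(=O)(=O)CC2=NCCS2)cc1`, 43.9% in this assay
compound 2 `COc1ccc(-c2nn(-c3ccccc3)c(-c3ccc(C)cc3)c2S(=O)(=O)CC2=NCCS2)cc1`, "not active" (no number reported) in this assay, with no number given

Compound 4 `COc1ccc(-c2nn(-c3ccccc3)c(-c3ccc(C)cc3)c2S(=O)(=O)CC2=NCCO2)cc1` has not yet been measured.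

Compounds 3 and 1 share one core and differ by a group of 5 heavy atoms (3 carbon, 1 nitrogen, 1 oxygen; one five-membered non-aromatic ring with 2 hetero atoms) in place of a group of 5 heavy atoms (3 carbon, 1 nitrogen, 1 sulfur; one five-membered non-aromatic ring with 2 hetero atoms), on a saturated chain carbon bound to a sulfonyl sulfur. This change gives a number 20.4 percentage points higher from compound 3 to compound 1 (beyond the scatter). Compound 2 carries a different core from compound 3; the difference between the two cores is not broken down here. Compound 4 is obtained from compound 2 by a group of 5 heavy atoms (3 carbon, 1 nitrogen, 1 oxygen; one five-membered non-aromatic ring with 2 hetero atoms) in place of a group of 5 heavy atoms (3 carbon, 1 nitrogen, 1 sulfur; one five-membered non-aromatic ring with 2 hetero atoms), on a saturated chain carbon bound to a sulfonyl sulfur, the same change as from compound 3 to compound 1, at the same place.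

From the compounds shown here alone, whether the step repeats on the core of compound 2 is unknown, and compound 2 itself offers no number to build on. Compound 4 is therefore expected to give a small read-out, 15%, roughly between 0% and 40%, with a fair chance that it is again reported only as not active.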

Compound 4, a percentage reported as activity, at one concentration (the size of the read-out at that concentration, not a potency): 68.7%
Compound 4: middle estimate off by 53.7 percentage points, on the low side, and the stated range ends below it.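

Within the data shown here, no step from compound 2 to compound 4 can be read, as compound 2 is reported only as not active in this assay. The compounds shown leave open how large the same ring exchange is on this core, and no evidence at hand bears on the result.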